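This account rests on a few compounds, and the source may have more. Where it says the series, first, only, none or still open, it means among the compounds named here.

Working notes on the series, measured in a functional assay on HL-60 cells (Homo sapiens) for inhibition; on this read-out higher numbers stand for weaker inhibition and lower numbers for stronger inhibition.

Compound 1 `CC1OC(OC2CCCCC2OCCCCC(C(=O)O)C(=O)O)C(O)C(O)C1O` returns only a limit of the assay in this assay, namely > 5000000 nM. Compound 2 `CC1OC(OC2CCCCC2OC(=O)NCCC(C(=O)O)C(=O)O)C(O)C(O)C1O` differs from compound 1 in that the ether linker is replaced by a carbamate linker. In this assay compound 2 gives 3400000 nM. Among the numbers shown, compound 2 carries the only measured value; the one other entry is the limit (the limit of > 5000000 nM in this assay, at which 1 of the 2 values shown sits), so no step between measured compounds can be stated.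

Compound 3 `CC1OC(OC2CCCCC2OC(=O)NCCCC(C(=O)O)C(=O)O)C(O)C(O)C1O` has not yet been measured. Its difference from compound 2 is 2,2-dicarboxyethyl in place of dicarboxymethyl on a saturated chain carbon, two bonds along the chain from an amide-type nitrogen. Within the data shown here, this is a chain extension by a single carbon, with the same donors and acceptors retained, and nothing among the measured compounds bears on a change of this kind.

The expectation for compound 3 in this assay is therefore a step from compound 2 of a 1.0-fold higher number from compound 2 to compound 3 (0.01 log units; within the scatter), no larger than the usual scatter. Compound 3 is estimated at 3500000 nM in this assay, within a range from 1000000 nM to 12000000 nM, with a fair chance that only a limit is returned.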

Compound 3, half-maximal inhibitory concentration: 1000000 nM
Compound 3: middle estimate off by 3.5-fold (0.54 log units), on the high side, and the stated range covers the measured number.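

In this assay, among these compounds, 2,2-dicarboxyethyl in place of dicarboxymethyl on a saturated chain carbon, two bonds along the chain from an amide-type nitrogen, gives a 3.4-fold lower number from compound 2 to compound 3 (0.53 log units; beyond the scatter) and is the first step that can be read. This place on the chain therefore responds to a change of a single carbon, even though the count of hydrogen-bond donors and acceptors stays the same and both carboxylic acids are kept, and the shift is towards stronger inhibition, though compound 3 still reads 1000000 nM as a high number on this scale. Compound 1, with the ether linker, remains a limit of the assay, so the steps to it cannot be read: the limit of > 5000000 nM in this assay, at which 1 of the 3 values shown sits.

The compounds shown leave open whether 3,3-dicarboxypropyl or 4,4-dicarboxybutyl at this place would lower the number further or reverse the step, since one step fixes no direction along a chain. Also open, on these data alone, is whether both acid groups are needed, as a single carboxylic acid or a primary amine at the chain end would test, and whether the step holds with the ether linker in place of the carbamate.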